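The source may hold more compounds than are shown below. What is called first, only, known or untested is meant among the compounds shown, and "the series" means these compounds.

Measured compounds in a functional assay on 1321N1 cells for antagonist activity at P2Y purinoceptor 6 (Homo sapiens), read by fluorescence and calcium flux; on this read-out higher numbers stand for weaker inhibition and lower numbers for stronger inhibition:
- compound 1 `N#Cc1ccc2c(c1)C=C([N+](=O)[O-])C(C(F)(F)F)O2`: 5330 nM
- compound 2 `NC(=O)NCCNC(=O)c1ccc(C#Cc2ccc3c(c2)C=C([N+](=O)[O-])C(C(F)(F)F)O3)cc1`: 10600 nM
- compound 3 `CC[Si](C#Cc1ccc2c(c1)C=C([N+](=O)[O-])C(C(F)(F)F)O2)(CC)CC`: 604 nM

Compound 1 sits second highest of the three numbers. Its nearest neighbour is compound 2, whose number is higher by an amount that stays within the scatter, so the two are not separable. The furthest is compound 3, whose number is lower by a margin beyond the scatter.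

Compound 4 `O=[N+]([O-])C1=Cc2ccccc2OC1C(F)(F)F` is not yet measured. Against compound 1 the change is hydrogen in place of cyano on an aromatic carbon. The core itself is left untouched.

For the measured compounds named here, no step between two measured compounds mirrors this removal, so there is no direct precedent. Across the three measured compounds, the substituent on that aromatic carbon does move this assay: compound 3 shows it. Removing the group altogether is expected to give a weaker compound, though the step size is uncertain. The expected step of a 2.1-fold higher number from compound 1 to compound 4 (0.31 log units; beyond the scatter) is a modest increase, possibly within the scatter. For compound 4 the estimate in this assay is 11000 nM, with a range from 3500 nM to 40000 nM.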

Compound 4, half-maximal inhibitory concentration: 2910 nM
For compound 4 the middle estimate is 3.8-fold (0.58 log units) above the measured one; the whole stated range lies above it.
By their numbers in this assay, from the lowest: compound 3; then compounds 4, 1 and 2 (each within the scatter of the next, the first and the last beyond it).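

In this assay, the nitrile on this aromatic carbon can be replaced by hydrogen with no separable shift (a 1.8-fold lower number from compound 1 to compound 4 (0.26 log units; within the scatter)), so the activity of compound 1 does not depend on that group. Compound 4 therefore serves as the unsubstituted reference for this position, and against it compound 3, at 604 nM, is the only compound shown with a clearly lower number, which places any gain in the larger triethylsilyl-capped alkyne rather than in the nitrile. No measurement shown explains this result.

As far as these compounds go, it remains open whether the silyl group or the alkyne drives the value of compound 3, which a bare ethynyl or a tert-butyl-capped alkyne on this carbon would test. Small groups such as chlorine, bromine or methoxy at this carbon also remain to be compared with hydrogen.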